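The compounds below may be only part of what the source reports. "The series", "measured", "known", "first", "only" and "open" are said of these compounds alone.

Compound 1 `CCCCCCCC(=O)Oc1cc(C(=O)C2=C3OC(C)(C)[C@@H](CC=C(C)C)C[C@@]34C[C@@H](CC=C(C)C)C(C)(C)[C@H]3CCC(C)(C)O[C@]34OC2=O)ccc1O`: > 20000 nM
Compound 2 `CC(C)=CC[C@H]1C[C@]23C[C@@H](CC=C(C)C)C(C)(C)[C@H]4CCC(C)(C)O[C@]42OC(=O)C(C(=O)c2ccc(O)c(O)c2)=C3OC1(C)C`: 13500 nM

Within the data shown here, in a functional assay on MCF7 cells (Homo sapiens) for antiproliferative activity, read by MTT assay, with a stated time of 72 h (a higher number here means a weaker inhibitor, a lower number a stronger inhibitor), compound 2 gives 13500 nM, the only exact number so far. For compound 1, the reading of > 20000 nM is a limit of the assay and not a number.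

Compound 3 `CCCCCC(=O)Oc1cc(C(=O)C2=C3OC(C)(C)[C@@H](CC=C(C)C)C[C@@]34C[C@@H](CC=C(C)C)C(C)(C)[C@H]3CCC(C)(C)O[C@]34OC2=O)ccc1O` differs from compound 2 by pentylcarbonyl in place of hydrogen on an oxygen on an aromatic ring. Among the measured compounds shown here, the one measured step that bears on this swaps heptylcarbonyl for hydrogen at such an oxygen, and it is an at least 1.4-fold lower number from compound 1 to compound 2 (0.17 log units; that floor lies within the scatter). Putting a chain back should therefore work the opposite way, so only a small upward step, possibly none beyond the scatter, is expected. The expected step is a 1.3-fold higher number from compound 2 to compound 3 (0.12 log units; within the scatter). For compound 3 the estimate is 18000 nM, with an expected range of 9000 nM to 36000 nM.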

Compound 3, half-maximal inhibitory concentration: 15500 nM
Compound 3: the middle estimate sits 1.2-fold (0.06 log units) above what was measured; low and high end bracket the measured number.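

In this assay, among these compounds, the pentylcarbonyl group on this oxygen gives the first exact comparison with the free hydroxy, and the step is a 1.1-fold higher number from compound 2 to compound 3 (0.06 log units; within the scatter) so this change shows no effect that can be told from scatter. Against the longer chain of compound 1, only a floor can be read, namely an at least 1.2-fold lower number from compound 1 to compound 3 (0.11 log units; that floor lies within the scatter) and nothing firmer. The reading of compound 1 is a limit and not a number: the limit of > 20000 nM in this assay, at which 1 of the 3 values shown sits.

Still open, on these data alone, is whether a shorter acetyl group, or an amine or a carboxylic acid carried on this oxygen, would move the value beyond the scatter.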